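Swapping Nitro for Amino on Two Related Cores

This account rests on a few compounds, and the source may have more. Where it says the series, first, only, none or still open, it means among the compounds named here.

Compound 1 `COc1ccc(-n2ccnc2-c2cc(OC)c(OC)c(OC)c2)cc1[N+](=O)[O-]` and compound 2 `COc1ccc(-n2ccnc2-c2cc(OC)c(OC)c(OC)c2)cc1N` share one core; in a functional assay on MDA-MB-468 cells (Homo sapiens) for antiproliferative activity, read by MTT assay, with a stated time of 72 h (a higher number here means a weaker inhibitor, a lower number a stronger inhibitor), compound 1 gives 100 nM and compound 2 gives 90 nM. The change between them is amino in place of nitro on an aromatic carbon and it made a step of a 1.1-fold lower number from compound 1 to compound 2 (0.05 log units; within the scatter). Compound 3 `COc1ccc(NC(=O)c2cc(OC)c(OC)c(OC)c2)cc1[N+](=O)[O-]` rests on a different core; the difference between the two cores is not broken down here. In this assay compound 3 gives 2900 nM, the highest of the three numbers. Compound 4 `COc1ccc(NC(=O)c2cc(OC)c(OC)c(OC)c2)cc1N` has not been measured; it differs from compound 3 by amino in place of nitro on an aromatic carbon, the same change made in the same surroundings. Since that change moved the number only within the scatter in a 1.1-fold lower number from compound 1 to compound 2 (0.05 log units; within the scatter), the step from compound 3 to compound 4 is expected to be a 1.1-fold lower number from compound 3 to compound 4 (0.05 log units; within the scatter). Compound 4 is therefore estimated to give 2600 nM in this assay, with a likely span from 1300 nM to 5200 nM.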

Compound 4, half-maximal inhibitory concentration: 2000 nM
Compound 4: middle estimate off by 1.3-fold (0.11 log units), on the high side; low and high end bracket the measured number.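

In this assay, replacing nitro with amino on the second core gave a 1.5-fold lower number from compound 3 to compound 4 (0.16 log units; within the scatter), so once again the number stayed within the usual scatter. Set beside the earlier case, the two steps agree: the same change on two cores in this assay, a 1.1-fold lower number (0.05 log units; within the scatter) from compound 1 to compound 2 and a 1.5-fold lower number (0.16 log units; within the scatter) from compound 3 to compound 4, 1.3-fold (0.12 log units) apart, within the scatter of two such steps. This shows that the change carried over between these two cores with little effect on the number, but two cores are a small sample, and they do not show why the effect is so small or whether it would hold on a third core.

The compounds shown leave open what other groups in the same place, such as a carboxylic acid or an acetamide, would do on either core. They also leave open whether the swap would behave alike with a chlorine atom in place of the methoxy group.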